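The source may report more compounds than this note shows. Statements on the series, on what has been measured and on what is new or still open speak of the compounds shown alone.

Measured in an ADME assay on THP-1 cells (Homo sapiens) for cytotoxicity, read by trypan blue exclusion, with a stated time of 48 h; on this read-out lower numbers stand for stronger inhibition of growth and higher numbers for weaker inhibition of growth:
compound 1 `Cc1cc(CNCc2ccc(F)cc2)c(C)n1-c1ccc(Cl)cc1`: 8.4 ug/mL
compound 2 `Cc1ccc(CNCc2cc(C)n(-c3ccc(Cl)cc3)c2C)cc1`: 6.1 ug/mL
compound 3 `Cc1cc(CNC2CCCCC2)c(C)n1-c1ccc(Cl)cc1`: 7.4 ug/mL

Compound 3, with a cyclohexyl on its amine nitrogen, has no clear rank among these three. Its steps from the other two are small: a 1.1-fold lower number from compound 1 to compound 3 (0.06 log units; within the scatter), and a 1.2-fold higher number from compound 2 to compound 3 (0.08 log units; within the scatter).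

Compound 4 `Cc1cc(CNCc2ccc(Cl)cc2)c(C)n1-c1ccc(Cl)cc1` keeps the core of compound 3 and changes one group, with 4-chlorobenzyl in place of cyclohexyl on an amine nitrogen. Among the compounds with values here, no measured compound carries this group, but those same two steps, read in reverse, are the closest guides, since each exchanges cyclohexyl with a related benzyl group. The exchange of fluoro for methyl on the benzyl ring was also small: a 1.4-fold lower number from compound 1 to compound 2 (0.14 log units; within the scatter). None of these steps gives a direction, so no change beyond the scatter is expected in this assay. The expected change is a 1.1-fold lower number from compound 3 to compound 4 (0.02 log units; within the scatter). For compound 4 the estimated value is 7 ug/mL, with an expected range of 3.6 ug/mL to 13.5 ug/mL.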

Compound 4, concentration for 50% growth inhibition: 18 ug/mL
Compound 4: the middle estimate sits 2.6-fold (0.41 log units) below what was measured; the measured number lies above the stated range.
By their numbers in this assay, from the lowest: compounds 2, 3 and 1 (each within the scatter of the next); then compound 4.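

In this assay, the group on the amine nitrogen had not yet made a clear difference, but 4-chlorobenzyl in place of cyclohexyl does (a step of a 2.4-fold higher number from compound 3 to compound 4 (0.39 log units; beyond the scatter)), meaning weaker inhibition of growth. The atom or group on the aromatic carbon of the benzyl ring also matters here: fluoro and methyl stayed within the scatter of each other, yet chloro stands apart from both (a 2.1-fold higher number from compound 1 to compound 4 (0.33 log units; beyond the scatter) and a 3.0-fold higher number from compound 2 to compound 4 (0.47 log units; beyond the scatter)). Nothing available explains why chloro behaves differently from the other two.

Going by these compounds, it remains open whether bromo or methoxy on that aromatic carbon would go with compound 4 or with compound 1 and compound 2. A plain benzyl on the amine nitrogen would show how much any substituent on this ring contributes.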